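Removing a Chloro Group from the Amide Aryl Ring

This account rests on a few compounds, and the source may have more. Where it says the series, first, only, none or still open, it means among the compounds named here.

Compound 1, `O=C(Nc1cccc(-n2cc(-c3ccncc3)c(-c3ccc(Cl)c(O)c3)n2)c1)Nc1ccc(Cl)c(Cl)c1`: 9680 nM in a functional assay on U-251 cells (Homo sapiens) for inhibition, read by sulforhodamine B assay, with a stated time of 48 h; a higher number here means a weaker inhibitor of growth, a lower number a stronger inhibitor of growth
Compound 2, `COc1cc(-c2nn(-c3cccc(NC(=O)c4ccc(Cl)c(C(F)(F)F)c4)c3)cc2-c2ccncc2)ccc1Cl`: a limit of > 32500 nM in this assay

Of the compounds shown here, two sharing a core have been measured in this assay. Compound 1 gives a number, 9680 nM. Compound 2 gives no number, only a limit, > 32500 nM, so its standing can be stated only as being at the limit of > 32500 nM in this assay, at which 1 of the 2 values shown sits. Among the measured compounds shown here, no pair of measured compounds differs in a single place, so there is no measured step to set the scale for what follows.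

Compound 3, `COc1cc(-c2nn(-c3cccc(NC(=O)c4cccc(C(F)(F)F)c4)c3)cc2-c2ccncc2)ccc1Cl`, is not yet measured. It differs from compound 2 by hydrogen in place of chloro on an aromatic carbon. Since compound 2 sits at the limit of this assay, there is no number to move from, and loss of one chloro group on the amide aryl ring is not expected to turn a compound at the limit into a strong growth inhibitor. The step from compound 2 to compound 3, a step that the limit leaves unreadable from compound 2 to compound 3, is expected to be none beyond the scatter, and compound 3 is expected to give about 35000 nM, within a range from 12000 nM to 90000 nM, most likely again reported as a limit.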

Compound 3, concentration for total growth inhibition: > 50000 nM
Compound 3: a limit, no number; the forecaster's own chance of this, stated with the estimate: 70%; middle value at least 1.4-fold (0.15 log units) from the limit.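

In this assay compound 2 gives > 32500 nM, which is a limit and not a number. Among the compounds shown here, compound 3 gives > 50000 nM, also a limit, and no step from compound 2 to compound 3 can be read. The compounds shown leave open whether hydrogen in place of chloro on the 4-chloro-3-(trifluoromethyl)phenyl group changes growth inhibition in this assay at all.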